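The source may hold more compounds than are shown below. What is called first, only, known or untested is meant among the compounds shown, and "the series" means these compounds.

Compound 3 `CCN1CC(NC(=O)[C@@H]2CCCN(S(=O)(=O)c3ccc(S(=O)(=O)N(CC)CC)cc3)C2)C1` carries an ethyl group on the nitrogen of its four-membered ring. In a functional assay on MIA PaCa-2 cells (Homo sapiens) for inhibition, read by MTT assay, with a stated time of 7 days (a higher number here means a weaker inhibitor, a lower number a stronger inhibitor), compound 3 reached only the limit of the test, > 30000 nM, so its true value is not known as a number. It is the compound sitting at the limit of > 30000 nM in this assay, at which 1 of the 3 values shown sits. Compound 2 `CCN(CC)S(=O)(=O)c1ccc(S(=O)(=O)N2CCC[C@@H](C(=O)NC3CN(C(=O)C4CC4)C3)C2)cc1` differs from it only in the group on that ring nitrogen; in this assay compound 2 gives 2800 nM. The step of an at least 10-fold higher number from compound 2 to compound 3 (1.02 log units; beyond the scatter) shows that replacing the cyclopropylcarbonyl with ethyl weakened inhibition strongly. Compound 1 `CCOC(=O)[C@@H]1CCCN(S(=O)(=O)c2ccc(S(=O)(=O)N3CCOCC3)cc2)C1`, a simpler relative without the four-membered ring, gives 23500 nM in this assay.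

Compound 4 `CCN(CC)S(=O)(=O)c1ccc(S(=O)(=O)N2CCC[C@@H](C(=O)NC3CN(C(=O)OC(C)(C)C)C3)C2)cc1` is reached from compound 3 by the change (tert-butoxycarbonyl in place of ethyl on an amine nitrogen in a ring). The entering group, like the cyclopropylcarbonyl of compound 2, joins the ring nitrogen through a carbonyl, whereas the ethyl of compound 3 does not. Among the compounds with values here, the only measured step that bears on this change is an at least 10-fold higher number from compound 2 to compound 3 (1.02 log units; beyond the scatter), which was large. Moving from an ethyl back to a carbonyl-bearing group is therefore expected to lower the number again. Compound 4 is expected to give about 5000 nM in this assay, between 1500 nM and 20000 nM. The expected step is an at least 6.0-fold lower number from compound 3 to compound 4 (0.77 log units; beyond the scatter).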

Compound 4, half-maximal inhibitory concentration: 200 nM
Compound 4: the middle estimate sits 25-fold (1.40 log units) above what was measured, outside the stated range (below it).
By their numbers in this assay, from the lowest: compound 4; then compound 2; then compound 1. At a limit, above all of these: compound 3.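

In this assay, placing tert-butoxycarbonyl on the amine nitrogen of the four-membered ring gives an at least 150-fold lower number from compound 3 to compound 4 (2.17 log units; beyond the scatter), which shows that the group on this nitrogen can shift the number very widely. Compound 3 enters that step only as a limit of the assay, so the true size of the step is not known: the limit of > 30000 nM in this assay, at which 1 of the 4 values shown sits.

Within the data shown here, the earlier compounds showed only that the cyclopropylcarbonyl of compound 2 and the ethyl of compound 3 differ, but the step of a 14-fold lower number from compound 2 to compound 4 (1.15 log units; beyond the scatter) now separates two groups that both join the nitrogen through a carbonyl, so that link alone does not set the number and the group on the carbonyl carbon matters as well.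

Going by these compounds, it remains open whether the gain comes from the oxygen of the tert-butoxy group or from its branched carbons, a question that a methoxycarbonyl or a pivaloyl group on the same nitrogen could help to separate. On these data alone, how a free amine at this nitrogen would compare with compound 2 and compound 4 also remains open.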